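The source may hold more compounds than are shown below. What is called first, only, known or untested is meant among the compounds shown, and "the series" means these compounds.

Compound 1 `CCOCC(=O)OCCc1c(-c2ccccc2Cl)c2cc(Cl)ccc2[nH]c1=O`: 130000 nM
Compound 2 `O=C(OCCc1c(-c2ccccc2Cl)c2cc(Cl)ccc2[nH]c1=O)C1CCCC1`: 46000 nM
Compound 3 `O=C(OCCc1c(-c2ccccc2Cl)c2cc(Cl)ccc2[nH]c1=O)C1CCCCC1`: 38000 nM

These three compounds share one core and differ only in the group attached to a carbonyl carbon of an ester. In an ADME assay on HepG2 2.2.15 cells (Homo sapiens) for cytotoxicity (a lower number here means that less compound is tolerated, a higher number that more compound is tolerated), compound 3 has the lowest number of the three, but its separation from compound 2 is small: a 1.2-fold lower number from compound 2 to compound 3 (0.08 log units; within the scatter). Against compound 1 the gap is clearer: a 3.4-fold lower number from compound 1 to compound 3 (0.53 log units; beyond the scatter).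

Compound 4 `O=C(COc1ccccc1)OCCc1c(-c2ccccc2Cl)c2cc(Cl)ccc2[nH]c1=O` has not yet been measured. It carries a change at the same carbonyl carbon: phenoxymethyl in place of cyclohexyl on a carbonyl carbon.

Among the compounds with values here, two measured steps bear on this. Replacing ethoxymethyl with a carbon ring lowered the number in each case: a 2.8-fold lower number from compound 1 to compound 2 (0.45 log units; beyond the scatter) and a 3.4-fold lower number from compound 1 to compound 3 (0.53 log units; beyond the scatter). The phenoxymethyl group of compound 4 pairs an aromatic ring with a hydrogen-bond acceptor, so it resembles the ethoxymethyl of compound 1 in one respect and the ring groups of compounds 2 and 3 in another. Within the data shown here, only three compounds are available, none with an aromatic group, so the outcome is uncertain.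

Compound 4 is therefore expected to lie between compound 1 and compound 3, with a modest rise: a 1.6-fold higher number from compound 3 to compound 4 (0.20 log units; within the scatter). In this assay compound 4 is estimated at 60000 nM, in a range from 25000 nM to 150000 nM.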

Compound 4, half-maximal cytotoxic concentration: 81000 nM
Compound 4: middle estimate off by 1.4-fold (0.13 log units), on the low side, within the range that was stated.
By their numbers in this assay, from the lowest: compounds 3, 2, 4 and 1 (each within the scatter of the next, the first and the last beyond it).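

In this assay, within the data shown here, phenoxymethyl brings an aromatic ring to this carbonyl carbon for the first time, and it gives a 2.1-fold higher number from compound 3 to compound 4 (0.33 log units; beyond the scatter), so a six-membered carbon ring does not by itself set the number at this position. The picture is less sharp against the other two groups, with a 1.8-fold higher number from compound 2 to compound 4 (0.25 log units; within the scatter) and a 1.6-fold lower number from compound 1 to compound 4 (0.21 log units; within the scatter), and both of these steps lie within the usual scatter. Swapping ethyl for phenyl on the oxygen of the ester side chain therefore produces no clear change, whereas cyclopentyl and cyclohexyl in place of ethoxymethyl both gave steps beyond the scatter, but compound 4 goes against a clean split between oxygen-bearing groups and carbon rings, since it stays within the scatter of compound 2 as well as compound 1.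

No measurement here gives a reason for these differences. Still open, from the compounds shown here alone, is whether a benzyl group, a plain phenyl group without the oxygen, or an amine or a carboxylic acid at this carbonyl carbon would give a number closer to compound 4 or to compound 3.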